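The compounds below may be only part of what the source reports. "The series", "measured", "known", "first", "only" and "open" are said of these compounds alone.

Measured so far in a functional assay on A549 cells (Homo sapiens) for antiproliferative activity, read by MTT assay, with a stated time of 72 h; on this read-out lower numbers stand for stronger inhibition and higher numbers for weaker inhibition:
- compound 1 `COc1cc2ncnc(Nc3cccc(C(F)(F)F)c3)c2cc1OCCCN1CCNCCNCCNCC1`: 15700 nM
- compound 2 `C#Cc1cccc(Nc2ncnc3cc(OC)c(OCCCN4CCNCCNCC4)cc23)c1`: > 50000 nM
- compound 3 `COc1cc2ncnc(Nc3ccc(F)c(Br)c3)c2cc1OCCCN1CCNCCNCC1`: 34300 nM

The entry for compound 2, > 50000 nM, is a limit of the assay and not a number. Of the two numeric values, compound 3 holds the higher at 34300 nM. Compound 1 lies lower at 15700 nM, and that gap is beyond the usual scatter.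

Next is compound 4 `COc1cc2ncnc(Nc3cccc(C(F)(F)F)c3)c2cc1OCCCN1CCNCCNCC1`, which keeps the side chain of compound 3 and changes the group on the nitrogen: 3-(trifluoromethyl)phenyl in place of 3-bromo-4-fluorophenyl on a nitrogen on an aromatic ring. Going by the values given here, the one measured step at this place is an at least 1.4-fold lower number from compound 2 to compound 3 (0.16 log units; that floor lies within the scatter). From the compounds shown here alone, it gives only a floor, so its true size remains open. Compound 1 carries the incoming 3-(trifluoromethyl)phenyl group and gives 15700 nM, but its side chain differs from that of compound 4, so it is only a loose guide.

A small move toward lower numbers in this assay is therefore expected, and it may not clear the scatter. The estimated change is a 1.3-fold lower number from compound 3 to compound 4 (0.12 log units; within the scatter). For compound 4 the expected value is 26000 nM, with an estimated range from 12000 nM to 55000 nM.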

Compound 4, half-maximal inhibitory concentration: 37300 nM
Estimate against measurement, compound 4: 1.4-fold (0.16 log units) below; low and high end bracket the measured number.
By their numbers in this assay, from the lowest: compound 1; then compounds 3 and 4 (each within the scatter of the next). At a limit, above all of these: compound 2.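

In this assay, 3-(trifluoromethyl)phenyl in place of 3-bromo-4-fluorophenyl on a nitrogen on an aromatic ring gives a step that lies within the scatter (a 1.1-fold higher number from compound 3 to compound 4 (0.04 log units; within the scatter)), so with the nine-membered ring held, the two compounds cannot be told apart. Going by these compounds alone, with 3-(trifluoromethyl)phenyl held, the nine-membered ring in place of the larger ring gives the only step so far that is both a true number and beyond the scatter (a 2.4-fold higher number from compound 1 to compound 4 (0.38 log units; beyond the scatter)), although it rests on this single pair. Trifluoromethyl in place of ethynyl on an aromatic carbon gives only a floor (an at least 1.3-fold lower number from compound 2 to compound 4 (0.12 log units; that floor lies within the scatter)), and its size cannot be read because the starting entry is a limit of the assay and not a number: the limit of > 50000 nM in this assay, at which 1 of the 4 values shown sits.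

From the compounds shown here alone, it remains open whether the larger ring gives the same step with 3-bromo-4-fluorophenyl or 3-ethynylphenyl on the nitrogen. Also open, going by these compounds, is how the series reads with a piperazine or morpholine at the end of the chain, with a longer or shorter chain, or with a chloro or methoxy group on the phenyl ring.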